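A few compounds are considered here, and "the series" means these few. Any claim that something is new, unique, unknown or untested is made for them only; others in the source may bear on it.

The four compounds share a closely related core and differ mainly in the amine attached to the aryl ring of the anilino substituent. Compound 1 `CN1CCN(c2ccc(Nc3ncc4c(n3)N(C3CCCC3)CC(=O)N4)cc2)CC1` carries a 4-methylpiperazin-1-yl group, and in an ADME assay on HEK293 cells (Homo sapiens) for inhibition, read by MTT assay, with a stated time of 48 h (on this read-out higher numbers stand for weaker inhibition and lower numbers for stronger inhibition), compound 1 reaches only a limit of the assay, > 30000 nM. Compound 2 `O=C1CN(C2CCCC2)c2nc(Nc3ccc(N4CCCCC4)cc3)ncc2N1` has piperidin-1-yl in its place, and in this assay compound 2 gives 25100 nM. The change between them is piperidin-1-yl in place of 4-methylpiperazin-1-yl on an aromatic carbon, and the step it made is an at least 1.1-fold lower number from compound 1 to compound 2 (0.07 log units; that floor lies within the scatter); since one of the two ends is a limit, as the limit of > 30000 nM in this assay, at which 1 of the 3 values shown sits, records, only a floor on the step can be stated.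

Compound 3 `CN1CCN(c2ccc(Nc3ncc4c(n3)N(C3CCCC3)CC(=O)N4C)nc2)CC1` is the counterpart of compound 1 whose core differs from that of compound 1 in more than one place; the difference between the two cores is not broken down here. For compound 3 in this assay the outcome is recorded as "not determined" (no result reported), so no number is available.

Compound 4 `CN1C(=O)CN(C2CCCC2)c2nc(Nc3ccc(N4CCCCC4)cn3)ncc21` relates to compound 3 by piperidin-1-yl in place of 4-methylpiperazin-1-yl on an aromatic carbon, the same kind of change as that from compound 1 to compound 2, but here placed on a six-membered aromatic ring with one nitrogen, two atoms from the ring nitrogen, rather than on a ring of carbon only. Given that compound 2 gives 25100 nM, compound 4 is expected to be a weak inhibitor as well, with an estimated value of 22000 nM, lying between 7000 nM and 30000 nM. Since compound 1 reaches only a limit of the assay, there is a real chance that for compound 4 too only a limit will be reported.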

Compound 4, half-maximal inhibitory concentration: > 30000 nM
Compound 4: no number, only a limit; the forecaster's own chance of this, stated with the estimate: 45%; middle value at least 1.3-fold (0.13 log units) away from the limit.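

Compound 4 reaches only a limit of this assay, > 30000 nM. For the compounds shown here, with no result reported for compound 3, no step from compound 3 to compound 4 can be read. This limit recurs among the compounds shown: the limit of > 30000 nM in this assay, at which 2 of the 4 values shown sit. What the compounds shown leave open is how much piperidin-1-yl in place of 4-methylpiperazin-1-yl changes the number on the ring with one nitrogen.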